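Triazole thioether series: benzoylmethyl on sulfur

This account rests on a few compounds, and the source may have more. Where it says the series, first, only, none or still open, it means among the compounds named here.

Compound 1 `COc1ccc(-n2c(S)nnc2-c2cc(OC)c(OC)c(OC)c2)cc1` is reported in a functional assay on PC-3 cells (Homo sapiens) for inhibition, read by MTT assay, with a stated time of 48 h (on this read-out higher numbers stand for weaker inhibition and lower numbers for stronger inhibition), only as a limit, > 60000 nM. Compound 2 `COc1ccc(-n2c(SC)nnc2-c2cc(OC)c(OC)c(OC)c2)cc1` is likewise reported in this assay as a limit, > 60000 nM. Among the measured compounds shown here, the single measured step, a step that the two limits leave unreadable from compound 1 to compound 2, therefore cannot be sized, as the limit of > 60000 nM in this assay, at which 2 of the 2 values shown sit, shows. Compound 3 `COc1ccc(-n2c(SCC(=O)c3ccccc3)nnc2-c2cc(OC)c(OC)c(OC)c2)cc1` differs from compound 1 by benzoylmethyl in place of hydrogen on a sulfur. No readable measured step bears on this change, so no direction beyond the scatter can be drawn in this assay. Compound 3 is expected at 40000 nM, between 5000 nM and 120000 nM. The step of an at least 1.5-fold lower number from compound 1 to compound 3 (0.17 log units; that floor lies within the scatter) is an estimate only, likely ending again at a limit.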

Compound 3, half-maximal inhibitory concentration: > 60000 nM
Compound 3: only a limit was reported (the forecaster's own chance of this, stated with the estimate: 60%); at least 1.5-fold (0.17 log units) between middle value and limit.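

Compound 3 gives only a limit in this assay, > 60000 nM. Among the compounds shown here, no step among compound 1, compound 2 and compound 3 can be read: the limit of > 60000 nM in this assay, at which 3 of the 3 values shown sit. The compounds shown leave open whether any group on the sulfur gives a readable value in this assay.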